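The compounds below may be only part of what the source reports. "The series", "measured", "known", "first", "only" and "open" are said of these compounds alone.

For the measured compounds named here, compound 2, with the structure `Cc1ccc(-c2nnc(-c3sc(-c4cccnc4)nc3C)o2)cc1`, is one of two compounds tested so far for how much of it cultured pancreatic cancer cells tolerate. In an ADME assay on PANC-1 cells (Homo sapiens) for cytotoxicity, read by MTT assay (a higher number here means that more compound is tolerated, a lower number that less compound is tolerated), compound 2 gives > 100 ug/mL, which is a limit of the assay and not a measured number. Its neighbour compound 1, with the structure `Cc1cccc(-c2nnc(-c3sc(-c4cccnc4)nc3C)o2)c1`, gives > 100 ug/mL in this assay, again a limit rather than a number. Going by the values given here, the one measured step between them, a step that the two limits leave unreadable from compound 1 to compound 2, is therefore unreadable in size; both values rest on (the limit of > 100 ug/mL in this assay, at which 2 of the 2 values shown sit).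

Compound 3, with the structure `Cc1ccccc1-c1nnc(-c2sc(-c3cccnc3)nc2C)o1`, carries the change (2-methylphenyl in place of 4-methylphenyl on an aromatic carbon). Among the compounds with values here, the only measured step is the unreadable one from compound 1 to compound 2, so it sets no size for the step from compound 2 to compound 3 in this assay; a step of no readable size is expected. Compound 3 is estimated at 150 ug/mL in this assay, with a range from 60 ug/mL to 400 ug/mL, most likely reported as a limit again.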

Compound 3, half-maximal cytotoxic concentration: > 100 ug/mL
Compound 3: a limit, no number (the forecaster's own chance of this, stated with the estimate: 80%); the middle value is on the limit's open side.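

Compound 3 also gives a limit of the assay rather than a number, so the steps among compound 1, compound 2 and compound 3 cannot be read in size: the limit of > 100 ug/mL in this assay, at which 3 of the 3 values shown sit. Left open is the concentration at which each compound would reach its half-maximal effect in this assay, and whether 2-methylphenyl, 3-methylphenyl and 4-methylphenyl differ there at all.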